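A Single Methyl on a Weak Growth Inhibitor

The source may report more compounds than this note shows. Statements on the series, on what has been measured and on what is new or still open speak of the compounds shown alone.

In a functional assay on cells (Cancer cell lines, Homo sapiens) for inhibition (a higher number here means a weaker inhibitor of growth, a lower number a stronger inhibitor of growth), compound 1 `Cc1cc(-c2nc3sc(C)cn3c2/C=N/NC(=N)N)c(C)s1` gives 4470 nM and compound 2 `N=C(N)N/N=C/c1c(-c2cccs2)nc2sccn12` gives 14800 nM as the highest of the two numbers. Compound 2 is therefore the weaker inhibitor of growth of this pair, by a gap beyond the scatter.

Compound 3 `Cc1cn2c(/C=N/NC(=N)N)c(-c3cccs3)nc2s1` has not yet been measured. It differs from compound 2 by methyl in place of hydrogen on an aromatic carbon of a five-membered aromatic ring with 1 nitrogen and 1 sulfur, next to the ring sulfur.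

For the measured compounds named here, no measured pair isolates this change, so its size in this assay can only be judged loosely. Going by the values given here, the sole guide is that compound 1 at 4470 nM lies under the number of compound 2, which points toward lower numbers rather than higher ones. A small expected step, not clearly beyond the scatter, is estimated as a 1.9-fold lower number from compound 2 to compound 3 (0.27 log units; within the scatter) in the direction of stronger inhibition. For compound 3 the estimated value is 8000 nM with an expected range from 3500 nM to 18000 nM for repeated measurements.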

Compound 3, concentration for 50% growth inhibition: 5750 nM
The estimate for compound 3 lay 1.4-fold (0.14 log units) above the measured number; low and high end bracket the measured number.
By their numbers in this assay, from the lowest: compounds 1 and 3 (each within the scatter of the next); then compound 2.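

In this assay, methyl in place of hydrogen on this aromatic carbon, next to the ring sulfur, now has a measured step of its own, a 2.6-fold lower number from compound 2 to compound 3 (0.41 log units; beyond the scatter), and this step is modest but lies beyond the scatter; the earlier pair differed in more than one place and could not isolate it. Thiophen-2-yl in place of 2,5-dimethylthiophen-3-yl, with this methyl present in both compounds, gives a 1.3-fold higher number from compound 1 to compound 3 (0.11 log units; within the scatter), so the change of thiophene group produces no step that can be separated from the scatter in this setting. Nothing measured here explains why the methyl shifts the number, and no independent data bear on this result.

The compounds shown leave open whether an ethyl group, a chlorine atom or a methoxy group on the same aromatic carbon would move the number further, or in the opposite direction. They also leave open whether the methyl step would hold with a phenyl ring in place of thiophen-2-yl.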